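Branching the Amide Chain: What Compound 4 Should Show

This account rests on a few compounds, and the source may have more. Where it says the series, first, only, none or still open, it means among the compounds named here.

compound 1 `C=CC1=C(C(=O)NCCC)C(c2ccc(F)cc2)OC1`: > 100000 nM
compound 2 `C=CC1=C(C(=O)NCCC)C(c2ccc(Cl)c(Cl)c2)OC1`: > 100000 nM
compound 3 `C=CC1=C(C(=O)NCC(C)C)C(c2ccc(F)cc2)OC1`: > 100000 nM

Of the compounds shown here, three have been tested in a functional assay on HeLa cells (Homo sapiens) for cytotoxicity, read by MTT assay, with a stated time of 24 h; a lower number here means a stronger inhibitor, a higher number a weaker inhibitor. Compound 1 gave only a limit of the assay, not a number. Compound 2 likewise gave only a limit. Compound 3 also gave only a limit. Taken together, these readings form (the limit of > 100000 nM in this assay, at which 3 of the 3 values shown sit).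

Compound 1 and compound 3 share one core and differ by methyl in place of hydrogen on a saturated chain carbon bound to two saturated chain carbons. With both readings at the limit, the step that the two limits leave unreadable from compound 1 to compound 3 cannot be sized. Compound 2 carries a different core; how it differs from compound 1 is not broken down here.

Compound 4 `C=CC1=C(C(=O)NCC(C)C)C(c2ccc(Cl)c(Cl)c2)OC1` has not yet been measured. It differs from compound 2 by methyl in place of hydrogen on a saturated chain carbon bound to two saturated chain carbons, the same change already seen from compound 1 to compound 3, at a place described in identical words.

Resting on (the limit of > 100000 nM in this assay, at which 3 of the 3 values shown sit), the expected step is a step that the limit leaves unreadable from compound 2 to compound 4. Compound 4 is therefore estimated at 150000 nM, most probably reported once more as a limit rather than a number, with a plausible span from 60000 nM to 400000 nM.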

Compound 4, half-maximal inhibitory concentration: 60100 nM
Beside the measured number, compound 4's estimate is 2.5-fold (0.40 log units) above it, and the stated range covers the measured number.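

In this assay, the methyl that turns propyl into isobutyl on the core of compound 2 gives an at least 1.6-fold lower number from compound 2 to compound 4 (0.22 log units; that floor lies within the scatter). That floor lies within the usual scatter, so this step alone does not establish a real gain, although the true step could be larger, since the reading for compound 2 is only a limit. The same change on the core of compound 1 cannot be read, so this series does not show whether the change carries from one core to the other, and most readings give no number to compare: the limit of > 100000 nM in this assay, at which 3 of the 4 values shown sit.

The compounds shown leave open whether a longer chain such as hexyl, or an amine or a carboxylic acid in place of the isobutyl, would give a lower number in this assay. A ring such as cyclohexyl on the amide nitrogen also remains an open case.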